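The compounds below may be only part of what the source reports. "The series", "measured", "known", "first", "only" and "open" are said of these compounds alone.

In an ADME assay on microsomes from liver (Rattus norvegicus) for metabolic stability, using NADPH, with a stated time of 10 min (a lower number here means that less of the compound is left, a higher number that more of the compound is left), three compounds that share a core have been measured. Compound 1 `NCCCCN(C[C@@H]1Cc2ncccc2CN1)[C@H]1CCCc2cccnc21` gives 55%, and compound 2 `CN(C[C@@H]1Cc2ncccc2CN1)[C@H]1CCCc2cccnc21` gives 1%. Compound 3 `NC(=O)NC/C=C\CN(C[C@H]1Cc2ncccc2CN1)[C@H]1CCCc2cccnc21` gives 1%, level with compound 2 at the digits shown and far from compound 1, whose number is much higher.

The next structure is compound 4 `c1cnc2c(c1)CN[C@@H](CN(CCCCNC1CCOCC1)[C@H]1CCCc3cccnc31)C2`. Relative to compound 3, the change is a group of 10 heavy atoms (8 carbon, 1 nitrogen, 1 oxygen; one six-membered non-aromatic ring with 1 hetero atom) in place of a group of 7 heavy atoms (4 carbon, 2 nitrogen, 1 oxygen; no ring), on a saturated chain carbon bound to an amine nitrogen. The group that enters, 3-((oxan-4-yl)amino)propyl, sits on a saturated chain carbon bound to an amine nitrogen.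

Going by the values given here, only one measured step bears on this change: a number 54 percentage points lower from compound 1 to compound 2 (beyond the scatter). That large step, beyond the scatter, replaces 3-aminopropyl with hydrogen at the same kind of place. Among the compounds with values here, compound 4 keeps this propyl-and-amine arrangement, but with an oxan-4-yl group on the amine, and no measured compound shows what that addition does. Read in reverse, the step from compound 1 to compound 2 suggests a rise, though probably a smaller one than the full size of that step, and the uncertainty is wide.

The expected change is a number 29 percentage points higher from compound 3 to compound 4 (beyond the scatter), an upward step beyond the scatter. Compound 4 is estimated at 30%, with an expected range from 5% to 60%.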

Compound 4, percent of the compound remaining: 49%
Compound 4: the middle estimate sits 19 percentage points below what was measured; measured number inside the range.
By their numbers in this assay, from the lowest: compounds 2 and 3 (each within the scatter of the next); then compounds 4 and 1 (each within the scatter of the next).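

In this assay, the change gives a number 48 percentage points higher from compound 3 to compound 4 (beyond the scatter), so a large group at this place, on a saturated chain carbon bound to an amine nitrogen, is compatible with a high number. Size alone does not sort these compounds: the group of 7 heavy atoms in compound 3 leaves it level with compound 2, which carries only a methyl group there, whereas 3-((oxan-4-yl)amino)propyl in compound 4 brings it within the scatter of compound 1, which carries 3-aminopropyl and gives 55%. Among these four compounds, the two that carry a propyl chain with an amine nitrogen are the two with high numbers, and neither of the others goes against this; no measurement shown here gives a reason for the pattern.

On these data alone, what remains open is whether the amine nitrogen, the propyl chain or both carry this effect, as a carboxylic acid or a hydroxyl group in place of that amine, or a longer chain, would be needed to separate them. As far as these compounds go, it is also open what the oxygen of the oxan-4-yl ring contributes, which a cyclohexyl group on the same amine would address.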